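Swapping the amide aryl group on a benzyl-bearing core

A few compounds are considered here, and "the series" means these few. Any claim that something is new, unique, unknown or untested is made for them only; others in the source may bear on it.

Measured compounds:
compound 1, `O=C(CN1CCN(c2nnc(Cc3ccncc3)c3ccccc23)CC1)Nc1cccc(F)c1`, 4600 nM
compound 2, `O=C(CN1CCN(c2nnc(Cc3ccncc3)c3ccccc23)CC1)Nc1ccc(Br)cc1`, 2710 nM
compound 3, `COc1ccc(NC(=O)CN2CCN(c3nnc(Cc4ccccc4)c4ccccc34)CC2)cc1OC`, "not active" (no number reported)

In a functional assay on A549 cells (Homo sapiens) for cytotoxicity, read by MTT assay, with a stated time of 72 h (a lower number here means a stronger inhibitor, a higher number a weaker inhibitor), compound 1 gives 4600 nM. Compound 2, which carries 4-bromophenyl in place of 3-fluorophenyl on the amide-type nitrogen, gives 2710 nM; the step of a 1.7-fold lower number from compound 1 to compound 2 (0.23 log units; within the scatter) shows that this aryl exchange left the read-out unchanged within the scatter. The core of compound 3 differs from that of compounds 1 and 2. In this assay compound 3 is reported as "not active" (no number reported), so no number stands for it.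

Compound 4, `O=C(CN1CCN(c2nnc(Cc3ccccc3)c3ccccc23)CC1)Nc1ccc(F)c(Cl)c1`, is compound 3 with 3-chloro-4-fluorophenyl in place of 3,4-dimethoxyphenyl on an amide-type nitrogen. Among the compounds with values here, the only measured step that bears on it is the aryl swap from compound 1 to compound 2 on the other core, and that step was within the scatter. Compound 3 has no number, so there is no anchor on the same core; the expectation rests on compounds 1 and 2 and on the inactivity of compound 3. For compound 4 a weak result is expected, estimated at 6000 nM with a range from 1500 nM to 30000 nM.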

Compound 4, half-maximal inhibitory concentration: "not active" (no number reported)
Compound 4 has no reported number here; no gap can be computed for the estimate.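

In this assay compound 3 and compound 4 are both reported as not active, so no new step can be read between them. On these data alone, whether any amide aryl group gives a measurable number on this core stays open. Nothing shown here accounts for this result.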